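A few compounds are considered here, and "the series" means these few. Any claim that something is new, unique, unknown or untested is made for them only; others in the source may bear on it.

In a functional assay on SGC-7901 cells (Homo sapiens) for inhibition, read by MTT assay, with a stated time of 72 h (a lower number here means a stronger inhibitor, a higher number a weaker inhibitor), compound 1 (`O=C1Nc2ccccc2/C1=C\C(=O)c1cccc(Cl)c1`) gives 8400 nM and compound 2 (`CC(C)C(=O)Nc1cccc(C(=O)/C=C2/C(=O)Nc3ccccc32)c1`) gives 8600 nM, so the two stand level within the scatter. Compound 3 (`C=CC(=O)Nc1cccc(C(=O)/C=C2/C(=O)Nc3ccccc32)c1`) keeps the core of compound 1 and changes one group: (vinylcarbonyl)amino in place of chloro on an aromatic carbon. Among the measured compounds shown here, the one measured step that bears on this change is a 1.0-fold higher number from compound 1 to compound 2 (0.01 log units; within the scatter), with (isopropylcarbonyl)amino in place of chloro on an aromatic carbon. That step stayed within the scatter, so no step beyond the scatter is expected in this assay. The expected step is a 1.1-fold lower number from compound 1 to compound 3 (0.05 log units; within the scatter). The estimated value for compound 3 is 7500 nM, with an expected range from 3000 nM to 16000 nM.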

Compound 3, half-maximal inhibitory concentration: 5700 nM
For compound 3 the middle estimate is 1.3-fold (0.12 log units) above the measured one, within the range that was stated.
By their numbers in this assay, from the lowest: compounds 3, 1 and 2 (each within the scatter of the next).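

In this assay, (vinylcarbonyl)amino in place of chloro stays within the scatter (a 1.5-fold lower number from compound 1 to compound 3 (0.17 log units; within the scatter)), so this aromatic carbon now carries a second amide-type group with no step beyond the scatter. The new change at the far end of that group, vinyl in place of isopropyl on a carbonyl carbon, also stays within the scatter (a 1.5-fold lower number from compound 2 to compound 3 (0.18 log units; within the scatter)), and the double bonds it brings give no clear shift here. No supporting data explain these small steps. Still open, going by these compounds, is whether an amine, a carboxylic acid or a longer chain on that carbonyl carbon would give a step beyond the scatter.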